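Swapping trifluoromethyl for methoxy: a lipophilicity step repeated

A few compounds are considered here, and "the series" means these few. Any claim that something is new, unique, unknown or untested is made for them only; others in the source may bear on it.

Three compounds in this set share an amide-linked ether scaffold and have been measured in a physicochemical assay for lipophilicity, read by HPLC, in phosphate buffer, measured as chromatographic lipophilicity, at pH 7.4; a higher number here means a more lipophilic compound, a lower number a more polar compound. Compound 1 `COc1ccc2nc(C)cc(OCC(=O)Nc3cc(C)cc(C)c3)c2c1` gives 5.64 in this assay. Compound 2 `Cc1cc(C)cc(NC(=O)COc2cc(C)nc3ccc(C(F)(F)F)cc23)c1` gives 6.67 in this assay, and compound 3 `COc1ccc2nc(C)cc(OCC(=O)Nc3ccc(Cl)c(C(F)(F)F)c3)c2c1` gives 6.22 in this assay. Compound 1 and compound 2 differ only as follows: methoxy in place of trifluoromethyl on an aromatic carbon. That change gave a number 1.03 log units lower from compound 2 to compound 1 (beyond the scatter). The difference between the cores of compound 3 and compound 2 is not broken down here.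

Compound 4 `COc1ccc2nc(C)cc(OCC(=O)Nc3ccc(Cl)c(OC)c3)c2c1` has not yet been measured in this assay. It differs from compound 3 in this way: methoxy in place of trifluoromethyl on an aromatic carbon. Going by the values given here, this is the same kind of change as the one from compound 2 to compound 1, but the surroundings differ: there the carbon was part of a fused or bridged system of two rings, meta to a fused ring and para to a fused ring, whereas here it is ortho to a chloro group and meta to a large group. Resting on the step from compound 2 to compound 1, a number 1.03 log units lower from compound 2 to compound 1 (beyond the scatter), a drop of similar size is expected, a number 0.97 log units lower from compound 3 to compound 4 (beyond the scatter). Compound 4 is therefore estimated at 5.25 in this assay, with a likely range from 4.8 to 5.7.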

Compound 4, distribution coefficient: 5.09
Compound 4: middle estimate off by 0.16 log units, on the high side, within the range that was stated.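

In this assay the swap of trifluoromethyl for methoxy gave a number 1.13 log units lower from compound 3 to compound 4 (beyond the scatter) and, on the other core, a number 1.03 log units lower from compound 2 to compound 1 (beyond the scatter) as well, so the drop appeared with similar large size in both surroundings. That is two pairs only: it shows that the change carried over between these two cores, not that it will do so on every core or at every position in this series. Nothing measured here accounts for the drop, so the reason for it stays unknown.

A further step, a number 0.55 log units lower from compound 1 to compound 4 (beyond the scatter) as well, comes from 4-chloro-3-methoxyphenyl in place of 3,5-dimethylphenyl on the amide-type nitrogen, and this single pair cannot show how that change behaves on other compounds. The compounds shown also leave open where a nitrile, an amine or a carboxylic acid at the same aromatic carbon would fall relative to methoxy and trifluoromethyl.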